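A few compounds are considered here, and "the series" means these few. Any claim that something is new, unique, unknown or untested is made for them only; others in the source may bear on it.

Compound 1 `Cc1cc(C)cc(-c2c(C)nn(-c3nc(-c4ccc(Cl)c(Cl)c4)c(SC(C)C)s3)c2C(=O)O)c1` gives 2700 nM in a functional assay on BJAB cells (Homo sapiens) for antiproliferative activity, with a stated time of 4 days; on this read-out higher numbers stand for an effect only at larger amounts of compound and lower numbers for an effect already at smaller amounts; compound 2 `Cc1nn(-c2nc(-c3ccc(Cl)c(Cl)c3)c(SC(C)C)s2)c(C(=O)O)c1-c1cncc(C#N)c1` gives 20000 nM; compound 3 `Cc1nn(-c2nc(-c3ccc(Cl)c(Cl)c3)c(SC(C)C)s2)c(C(=O)O)c1-c1cnccn1` gives 14000 nM, the second highest of the three numbers, its nearest neighbour being compound 2 and its furthest compound 1. The step of a 5.2-fold higher number from compound 1 to compound 3 (0.71 log units; beyond the scatter) lies beyond the scatter, whereas a 1.4-fold lower number from compound 2 to compound 3 (0.15 log units; within the scatter) stays within it. Compound 4 `Cc1cc(-c2c(C)nn(-c3nc(-c4ccc(Cl)c(Cl)c4)c(SC(C)C)s3)c2C(=O)O)cc(C)n1` differs from compound 3 only in 2,6-dimethylpyridin-4-yl in place of pyrazin-2-yl on an aromatic carbon. The entering group restores the methyl pattern of the 3,5-dimethylphenyl of compound 1 on a ring with one nitrogen, so the step 1>3 bears most on it, and a lower number than compound 3 is expected, though with a single nitrogen-bearing ring retained the full return to compound 1 is uncertain. The expected step is a 3.1-fold lower number from compound 3 to compound 4 (0.49 log units; beyond the scatter). Compound 4 is therefore estimated at 4500 nM, with a range from 1500 nM to 13000 nM.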

Compound 4, half-maximal effective concentration: 580 nM
Compound 4: the middle estimate sits 7.8-fold (0.89 log units) above what was measured, and the stated range ends above it.
By their numbers in this assay, from the lowest: compound 4; then compound 1; then compounds 3 and 2 (each within the scatter of the next).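

On the aromatic carbon next to the ring atom bearing the carboxy group, this assay gives a 24-fold lower number from compound 3 to compound 4 (1.38 log units; beyond the scatter) and a 34-fold lower number from compound 2 to compound 4 (1.54 log units; beyond the scatter) on entry of 2,6-dimethylpyridin-4-yl, so a ring nitrogen in this group does not by itself bring the high numbers of compounds 2 and 3. The same group also passes 3,5-dimethylphenyl, with a 4.7-fold lower number from compound 1 to compound 4 (0.67 log units; beyond the scatter) and thus the lowest number of the four. Nothing available accounts for these steps. Still open, going by these compounds, is whether the two methyl groups or the ring nitrogen carry the drop, and what an amino group in place of one methyl would give.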